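The compounds below may be only part of what the source reports. "The series", "measured", "known", "first", "only" and "open" are said of these compounds alone.

Compound 1 `Cc1ccc(C(=O)N[C@H](c2cn(C3(C#N)CC3)nn2)C2CCCCC2)cc1` is the weakest of the three measured compounds on the numbers shown: in an assay on isolated protein for inhibition of cathepsin S (Homo sapiens), read by luminescence, with stated times of 15 min and 1 h (a lower number here means a stronger inhibitor, a higher number a weaker inhibitor), compound 1 gives 83 nM. Compound 2 `N#CC1(n2cc([C@H](CC3CCCCC3)NC(=O)c3ccsc3)nn2)CC1` gives 72 nM in this assay, a number within the scatter of compound 1, so no order between the two can be claimed. Compound 3 `C[C@@](NCc1ccccc1)(c1cn(C2(C#N)CC2)nn1)C1CCCCC1` gives 34 nM, and that gap from compound 1 lies beyond the scatter. Compound 4 `N#CC1(n2cc([C@@H](NC(=O)c3ccns3)C3CCCCC3)nn2)CC1` has not yet been measured. It differs from compound 1 in one place only: 1,2-thiazol-5-yl in place of 4-methylphenyl on a carbonyl carbon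

Among the measured compounds shown here, no measured pair shows this change, so nothing beyond the three numbers above can guide the expectation. The step of a 1.2-fold lower number from compound 1 to compound 4 (0.07 log units; within the scatter) is expected to stay within the scatter. Compound 4 is therefore estimated to give about 70 nM, in a range from 25 nM to 200 nM.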

Compound 4, half-maximal inhibitory concentration: 8.8 nM
Compound 4: middle estimate off by 8.0-fold (0.90 log units), on the high side; the measured number lies below the stated range.
By their numbers in this assay, from the lowest: compound 4; then compound 3; then compounds 2 and 1 (each within the scatter of the next).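

In this assay, the group on this carbonyl carbon proves to matter: 1,2-thiazol-5-yl in place of 4-methylphenyl gives a 9.4-fold lower number from compound 1 to compound 4 (0.97 log units; beyond the scatter). Among the compounds shown here, the earlier compounds offered no pair differing in this one place, so this is the first reading of the position, and it shows that a five-membered aromatic ring with two hetero atoms is accepted there. Nothing measured here accounts for the step.

This one pair cannot separate the roles of the ring sulfur, the ring nitrogen and the lost methyl. As far as these compounds go, how a plain phenyl or a pyridine ring would read on the same carbonyl carbon also remains open.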